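This account rests on a few compounds, and the source may have more. Where it says the series, first, only, none or still open, it means among the compounds named here.

Among the compounds with values here, in an ADME assay on the whole organism (strain Sprague-Dawley) for pharmacokinetics, with Rattus norvegicus as the target, using cassette dosing, at a dose of 1 mg/kg by the oral route (a higher number here means that a larger share of the oral dose reaches the circulation, a lower number that a smaller share of the oral dose reaches the circulation), compound 1 (`O=c1[nH]c2ccc(-c3cc(C[C@]4(O)CC[C@@H](Cc5ccccc5)CC4)no3)cc2o1`) gives 8.4%, while compound 2 (`O[C@]1(Cc2cc(-c3cn[nH]c3)on2)CC[C@H](Cc2ccccc2)CC1`) gives 46.3%, the higher of the two numbers so far. Within the data shown here, the only measured step, a number 37.9 percentage points higher from compound 1 to compound 2 (beyond the scatter), is large and beyond the scatter, but it concerns a different part of the molecule, a group exchanged on an aromatic carbon. Compound 3 (`O[C@]1(Cc2cc(-c3cn[nH]c3)on2)CC[C@H](Cc2ccc(F)cc2)CC1`) departs from compound 2 elsewhere: fluoro in place of hydrogen on an aromatic carbon. This is fluoro in place of hydrogen on an aromatic carbon, which turns benzyl to 4-fluorobenzyl. Among the measured compounds shown here, no measured step touches this position, so the large step offers no measure of this change, and the expectation rests on compound 2 at 46.3%. From the compounds shown here alone, the estimated change, a number 1.3 percentage points lower from compound 2 to compound 3 (within the scatter), is not expected to go beyond the scatter, and its direction remains open. For compound 3 the expected value is 45%, with an estimated range of 25% to 65%.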

Compound 3, oral bioavailability: 78%
Beside the measured number, compound 3's estimate is 33 percentage points below it; measured number outside the range, above it.
By their numbers in this assay, from the lowest: compound 1; then compound 2; then compound 3.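

In this assay, the change from benzyl to 4-fluorobenzyl gives a number 31.7 percentage points higher from compound 2 to compound 3 (beyond the scatter), so 1 fluorine atom in place of hydrogen on this six-membered aromatic ring of carbon only is enough for a large step. The earlier step had shown the number moving only with an exchange elsewhere in the molecule, and this result shows that the benzyl group is also a place where the share of the oral dose reaching the circulation responds. Nothing available here accounts for the rise, so its cause remains unknown. From the compounds shown here alone, whether a chloro or a methoxy group in the same place would give a similar number remains open. Also open is whether the fluoro would have a like effect alongside the group that compound 1 carries, as compound 3 is the only fluoro compound shown.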